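The compounds below may be only part of what the source reports. "The series", "measured", "known", "first", "only" and "open" are said of these compounds alone.

Measured in a functional assay on MIA PaCa-2 cells (Homo sapiens) for inhibition, read by MTT assay, with a stated time of 72 h; on this read-out lower numbers stand for stronger inhibition and higher numbers for weaker inhibition:
- compound 1 `COc1cc(NC(C)CCCNC(=O)Nc2cccc(Cl)c2)c2ncccc2c1`: 21000 nM
- compound 2 `COc1cc(NC(C)CCCNC(=O)NNC(=O)Nc2ccc(Cl)cc2)c2ncccc2c1`: >= 250000 nM (a limit)
- compound 3 `COc1cc(NC(C)CCCNC(=O)Nc2cc(C(F)(F)F)cc(C(F)(F)F)c2)c2ncccc2c1`: 4700 nM

Compound 2 stands at the limit of >= 250000 nM in this assay, at which 1 of the 3 values shown sits; this is a limit and not a number.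

Compound 4 `COc1cc(NC(C)CCCNC(=O)NNC(=O)Nc2cccc(F)c2)c2ncccc2c1` differs from compound 2 by 3-fluorophenyl in place of 4-chlorophenyl on an amide-type nitrogen. Among the compounds with values here, the one measured step that bears on this is an at least 11-fold higher number from compound 1 to compound 2 (1.07 log units; beyond the scatter). It is large, but it reflects a different change, and it sets compound 4 among the weak members of the series. Compound 1 gives 21000 nM and compound 3 gives 4700 nM, so the values do shift when the aryl group differs. A modest move to a lower number in this assay is therefore expected, or none that can be read against the limit. The expected change is an at least 1.6-fold lower number from compound 2 to compound 4 (0.22 log units; that floor lies within the scatter). For compound 4 the estimate is 150000 nM, with an expected range of 40000 nM to 250000 nM.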

Compound 4, half-maximal inhibitory concentration: 69000 nM
Compound 4: middle estimate off by 2.2-fold (0.34 log units), on the high side; the range from low to high includes it.
By their numbers in this assay, from the lowest: compound 3; then compound 1; then compound 4. At a limit, above all of these: compound 2.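

Replacing 4-chlorophenyl with 3-fluorophenyl on the amide-type nitrogen gives a readable value in this assay, with an at least 3.6-fold lower number from compound 2 to compound 4 (0.55 log units; beyond the scatter), so the aryl group still moves the value once the ((aryl)carbamoyl)amino unit is present. Even so, the unit does not match the directly attached aryl group, with a 3.3-fold higher number from compound 1 to compound 4 (0.52 log units; beyond the scatter), a modest rise in the number. Compound 2 remains a limit and not a number: the limit of >= 250000 nM in this assay, at which 1 of the 4 values shown sits.

On these data alone, whether the gain follows the halogen or its ring position stays open, since both change together. Also open, as far as these compounds go, is how a carboxylic acid or a dimethylamino group on this phenyl ring would read.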